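From 4-fluorophenyl to benzyloxy on the amide nitrogen

A few compounds are considered here, and "the series" means these few. Any claim that something is new, unique, unknown or untested is made for them only; others in the source may bear on it.

- compound 1 `COc1cc2nccc(Oc3ccc(Nc4nn(C)cc4C(=O)NC45CCC(CC4)CC5)cc3)c2cc1C(N)=O` gives > 10000 nM as a limit of the assay, not a number
- compound 2 `COc1cc2nccc(Oc3ccc(Nc4nn(C)cc4C(=O)NC4CCCCCCC4)cc3)c2cc1C(N)=O` gives 3210 nM
- compound 3 `COc1cc2nccc(Oc3ccc(Nc4nn(C)cc4C(=O)Nc4ccc(F)cc4)cc3)c2cc1C(N)=O` gives 3060 nM

In a functional assay on BaF3 cells (Mus musculus) for antiproliferative activity, read by CCK-8 assay and cell counting, with a stated time of 76 h (on this read-out higher numbers stand for weaker inhibition and lower numbers for stronger inhibition), compound 3 at 3060 nM stands level with compound 2 at 3210 nM within the scatter. Changing the group on the amide of compound 1 gave two larger steps (an at least 3.1-fold lower number from compound 1 to compound 2 (0.49 log units; beyond the scatter) and an at least 3.2-fold lower number from compound 1 to compound 3 (0.51 log units; beyond the scatter)) that lie beyond the scatter. Compound 4 `COc1cc2nccc(Oc3ccc(Nc4nn(C)cc4C(=O)NOCc4ccccc4)cc3)c2cc1C(N)=O` has benzyloxy in place of 4-fluorophenyl on an amide-type nitrogen. The closest measured swap on that nitrogen (a 1.0-fold lower number from compound 2 to compound 3 (0.02 log units; within the scatter)) stayed within the scatter, so no step beyond it is expected. The expected change (a 1.1-fold higher number from compound 3 to compound 4 (0.06 log units; within the scatter)) is small. Compound 4 is estimated at 3500 nM (expected range 1200 nM to 10000 nM).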

Compound 4, half-maximal inhibitory concentration: > 10000 nM
Compound 4 was reported as a limit; the forecaster's own chance of this, stated with the estimate: 20%; middle value at least 2.8-fold (0.45 log units) from the limit.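

In this assay, this nitrogen proves sensitive to a change that keeps an aromatic ring, with an at least 3.2-fold higher number from compound 3 to compound 4 (0.51 log units; beyond the scatter) and an at least 3.1-fold higher number from compound 2 to compound 4 (0.49 log units; beyond the scatter). Compound 3 and compound 4 each carry one six-membered aromatic ring of carbon only, so that ring alone does not preserve the activity seen with compound 3. Compound 1 and compound 4 both stand as limits, not numbers, so the step between them cannot be read: the limit of > 10000 nM in this assay, at which 2 of the 4 values shown sit.

As far as these compounds go, what remains open is whether the oxygen of benzyloxy matters or the longer link to the ring. A plain benzyl group on this nitrogen would help separate the two.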